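Swapping methyl for phenyl on the ring nitrogen

The compounds below may be only part of what the source reports. "The series", "measured", "known", "first", "only" and "open" are said of these compounds alone.

Of the compounds shown here, three built on a shared core have been tested in a functional assay, with a stated time of 20 min, tested at 0.5 mM; a lower number here means a weaker effect, a higher number a stronger effect of the compound at the concentration tested. Compound 1 `NCCNC(=O)c1c(O)c2ccccc2n(-c2ccccc2)c1=O` gives 1.4%, compound 2 `NCCCCCCNC(=O)c1c(O)c2ccccc2n(-c2ccccc2)c1=O` gives 19.3%, and compound 3 `Cn1c(=O)c(C(=O)Nc2ccccc2N)c(O)c2ccccc21` gives 28.8%. Compound 3 has the highest number of the three, yet its gap to compound 2 lies within the scatter, while its gap to compound 1 lies beyond it. Among the measured compounds shown here, the only measured step, a number 17.9 percentage points higher from compound 1 to compound 2 (beyond the scatter), concerns the chain on the amide-type nitrogen and not the ring nitrogen.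

Compound 4 `Nc1ccccc1NC(=O)c1c(O)c2ccccc2n(-c2ccccc2)c1=O` differs from compound 3 by phenyl in place of methyl on an aromatic nitrogen. For the measured compounds named here, no measured step isolates this change: compounds 1 and 2 do carry a phenyl on that nitrogen, but they differ from compound 3 elsewhere, so their lower numbers cannot be attributed to the phenyl. With nothing in the data pointing either way, the expected step is a number 1.2 percentage points higher from compound 3 to compound 4 (within the scatter), within the scatter. Compound 4 is therefore estimated to give 30% in this assay, within a range from 10% to 50%.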

Compound 4, a percentage reported as activity, at one concentration (the size of the read-out at that concentration, not a potency): 21.3%
For compound 4 the middle estimate is 8.7 percentage points above the measured one; measured number inside the range.
By their numbers in this assay, from the lowest: compound 1; then compounds 2, 4 and 3 (each within the scatter of the next).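

In this assay the swap of methyl for phenyl on the aromatic nitrogen gives a number 7.5 percentage points lower from compound 3 to compound 4 (within the scatter) and so, with 2-aminophenyl on the amide-type nitrogen, the two groups cannot be told apart, although phenyl brings 6 heavy atoms where methyl has 1. With phenyl kept on that nitrogen, 2-aminophenyl in place of 6-aminohexyl on the amide-type nitrogen gives a number 2 percentage points higher from compound 2 to compound 4 (within the scatter) and again separates nothing, while 2-aminophenyl in place of 2-aminoethyl gives a number 19.9 percentage points higher from compound 1 to compound 4 (beyond the scatter) and sets compound 1 apart from the other two phenyl compounds. No measurement shown here says why the numbers fall as they do.

Still open, going by these compounds, is how other groups on the aromatic nitrogen, such as ethyl or benzyl, would read, and how a carboxylic acid on that phenyl ring would. A read-out at one concentration also shows only a stronger or weaker effect at that concentration and leaves the effect at any other concentration open.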